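The source may report more compounds than this note shows. Statements on the series, on what has been measured and on what is new or still open speak of the compounds shown alone.

For the measured compounds named here, compound 2 `OCCOCn1ccc2c(Cl)nc(Cl)nc21` gives 100000 nM in a functional assay on HFF cells (Homo sapiens) for cytotoxicity (a lower number here means a stronger inhibitor, a higher number a weaker inhibitor), and that is the only plain number in hand. Compound 1 `COc1nc(N)c2ccn(COCCO)c2n1` reaches only a limit there, > 100000 nM. Its value is the limit of > 100000 nM in this assay, at which 1 of the 2 values shown sits. Compound 3 `Nc1nc(Cl)nc2c1ccn2COCCO` differs from compound 2 by amino in place of chloro on an aromatic carbon. Going by the values given here, no measured pair shows what this change does, so nothing points to a gain or a loss. In this assay a step of no change at the digits printed from compound 2 to compound 3 (within the scatter) is expected, which means none beyond the scatter. For compound 3 the estimate in this assay is 100000 nM, between 30000 nM and 300000 nM.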

Compound 3, half-maximal inhibitory concentration: > 100000 nM
Compound 3: a limit, no number; the forecaster's own chance of this, stated with the estimate: 60%; the middle value lies on the limit itself.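

In this assay, amino in place of chloro on an aromatic carbon gives a number no lower from compound 2 to compound 3 (the limit leaves the size open), so this swap brings no sign of stronger cytotoxicity. The step from compound 1 to compound 3 runs between two limits and cannot be read. Most of the series now sits at the same ceiling: the limit of > 100000 nM in this assay, at which 2 of the 3 values shown sit.

Going by these compounds, how far compound 3 really lies from compound 2 stays open. So does whether a carboxylic acid or a longer amine chain at this position would bring the number down into a measurable range.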